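This account rests on a few compounds, and the source may have more. Where it says the series, first, only, none or still open, it means among the compounds named here.

Compound 1 `CCC1C(=O)N(C)c2cnc(-n3ccc4cc(C(N)=O)ccc43)nc2N1c1ccn(C)n1` is the weaker of the two compounds for which a number exists. In a functional assay on HeLa cells (Homo sapiens) for antiproliferative activity, read by CCK-8 assay, with a stated time of 72 h (on this read-out lower numbers stand for stronger inhibition of growth and higher numbers for weaker inhibition of growth), compound 1 gives 27400 nM, the highest of the two values recorded. For the measured compounds named here, the other measured compound, compound 2 `CC[C@@H]1C(=O)N(C)c2cnc(-n3ccc4cc(C(=O)NC5CCCC5)ccc43)nc2N1C1CCCC1`, differs from compound 1 in more than one place, so no single step joins them; in this assay compound 2 gives 247 nM, a value far below that of compound 1 and well beyond the scatter.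

Compound 3 `CCNC(=O)c1ccc2c(ccn2-c2ncc3c(n2)N(c2ccn(C)n2)C(CC)C(=O)N3C)c1` is the single-change neighbour of compound 1, with ethyl in place of hydrogen on an amide-type nitrogen. Going by the values given here, no measured pair isolates this change, so the size and direction of its effect are unknown; the only hint is that compound 2, which also carries a carbon substituent on that amide nitrogen among its other differences, sits at 247 nM. The author therefore expects compound 3 to show a modest improvement, a step of a 2.7-fold lower number from compound 1 to compound 3 (0.44 log units; beyond the scatter) that may or may not clear the scatter. For compound 3 the estimate in this assay is 10000 nM, within a range of 3000 nM to 30000 nM.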

Compound 3, concentration for 50% growth inhibition: 11100 nM
Compound 3: middle estimate off by 1.1-fold (0.05 log units), on the low side; the range from low to high includes it.
By their numbers in this assay, from the lowest: compound 2; then compound 3; then compound 1.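

In this assay, for the compounds shown here, this measurement gives the first direct reading of a change at the amide-type nitrogen: ethyl in place of hydrogen gives a 2.5-fold lower number from compound 1 to compound 3 (0.39 log units; beyond the scatter) and so moves the number in the direction of stronger growth inhibition. The step is modest but lies beyond the scatter, so in this pair the amide hydrogen is not needed to keep activity, and the nitrogen accepts a two-carbon chain without loss, with compound 3 at 11100 nM in the same high range as its parent. No measurement is available that accounts for the direction or size of this step.

As far as these compounds go, it remains open whether a longer chain such as propyl, a branched group such as isopropyl, or a chain ending in an amine or a carboxylic acid would extend, hold or reverse this gain. From the compounds shown here alone, it is also open whether ethyl would give a similar step with other groups elsewhere on the shared core, and compound 2, which differs from compound 1 in more than one place, does not settle that.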